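Methoxy to Trifluoromethyl: Expecting Another Limit

The source may report more compounds than this note shows. Statements on the series, on what has been measured and on what is new or still open speak of the compounds shown alone.

Measured compounds in a functional assay on MCF7 cells (Homo sapiens) for cytotoxicity, with a stated time of 72 h; on this read-out higher numbers stand for weaker inhibition and lower numbers for stronger inhibition:
- compound 1, `CC(C)[C@H](NC(=O)c1cc(Cl)ccc1O)C(=O)Nc1ccc(Cl)cc1`, gives > 10000 nM
- compound 2, `C[C@H](NC(=O)c1cc(Cl)ccc1O)C(=O)Nc1ccc(C(F)(F)F)cc1`, gives > 12500 nM
- compound 3, `COc1ccc(NC(=O)[C@@H](NC(=O)c2cc(Cl)ccc2O)C(C)C)cc1`, gives > 10000 nM

Each of these three values is a limit of the assay and not a number. Compound 3 therefore stands only at a limit, and the two other values shown are limits as well, so no order among the three can be read. For the measured compounds named here, the one step that joins two measured compounds, a step that the two limits leave unreadable from compound 1 to compound 3, cannot be sized: both ends sit at limits, as the limit of > 10000 nM in this assay, at which 2 of the 3 values shown sit, records.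

Compound 4, `CC(C)[C@H](NC(=O)c1cc(Cl)ccc1O)C(=O)Nc1ccc(C(F)(F)F)cc1`, is not yet measured. It differs from compound 3 by trifluoromethyl in place of methoxy on an aromatic carbon. Going by the values given here, the only measured step bears on this change indirectly, and its size is unreadable. Compound 2 already carries the trifluoromethyl group on a closely related core, and compound 2 gives a limit in this assay; compound 1 with chloro at the same place gives a limit too. Among the compounds with values here, nothing among the measured compounds points to a readable step in either direction, so the expected step that the limit leaves unreadable from compound 3 to compound 4 is none beyond the scatter, and compound 4 is expected to come out as a limit again. Compound 4 is estimated at 20000 nM, within 8000 nM to 60000 nM.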

Compound 4, half-maximal inhibitory concentration: 7300 nM
Estimate against measurement, compound 4: 2.7-fold (0.44 log units) above, outside the stated range (below it).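

In this assay compound 4 gives 7300 nM as the only number among the compounds shown, so trifluoromethyl at this place, para to a large group, with isopropyl on the chain, is the first combination to give a readable value rather than a limit. Each change into compound 4 can be stated only as a floor: trifluoromethyl in place of methoxy gives an at least 1.3-fold lower number from compound 3 to compound 4 (0.13 log units; that floor lies within the scatter) and trifluoromethyl in place of chloro gives an at least 1.3-fold lower number from compound 1 to compound 4 (0.13 log units; that floor lies within the scatter) while isopropyl in place of methyl gives an at least 1.7-fold lower number from compound 2 to compound 4 (0.23 log units; that floor lies within the scatter) on the other side of the comparison. As far as these compounds go, the other end of each step is a limit and not a number, so the true sizes stay unknown because of where those values sit: the limit of > 10000 nM in this assay, at which 2 of the 4 values shown sit, and (the limit of > 12500 nM in this assay, at which 1 of the 4 values shown sits).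

From the compounds shown here alone, the step joining the two limits of compound 1 and compound 3 still cannot be read, and it remains open how far each floor understates its step and whether the number for compound 4 depends on trifluoromethyl, on isopropyl or on both. Also open, going by these compounds, is how an amine, a carboxylic acid or a nitrile at this place, or a longer chain in place of isopropyl, would read in this assay on the same core.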